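A shorter acid chain on the shared core

This account rests on a few compounds, and the source may have more. Where it says the series, first, only, none or still open, it means among the compounds named here.

In a physicochemical assay for solubility, read by nephelometry, measured as kinetic solubility, with a stated time of 30 min, at pH 2.0 (a lower number here means a less soluble compound, a higher number a more soluble compound), compound 1 (`CCOC(=O)COc1ccc([C@H]2CC[C@]3(CC2)OOC2(O3)C3CC4CC(C3)CC2C4)cc1`) gives < 0.78 ug/mL, which is a limit. Compound 2 (`O=C(O)CCCCOc1ccc([C@H]2CC[C@]3(CC2)OOC2(O3)C3CC4CC(C3)CC2C4)cc1`) gives < 1.6 ug/mL, which is also a limit. For the measured compounds named here, the only measured step is a step that the two limits leave unreadable from compound 1 to compound 2, so it offers no size to carry forward. Compound 3 (`O=C(O)c1ccc([C@H]2CC[C@]3(CC2)OOC2(O3)C3CC4CC(C3)CC2C4)cc1`) differs from compound 2 by carboxy in place of 4-carboxybutoxy on an aromatic carbon, with carboxy in place of 4-carboxybutoxy on an aromatic carbon. Without a readable step, no firm direction can be drawn, and the expected change is modest. The estimated step is a step that the limit leaves unreadable from compound 2 to compound 3. In this assay the estimated value for compound 3 is 1.5 ug/mL, with an expected range from 0.5 ug/mL to 6 ug/mL.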

Compound 3, solubility: < 1.6 ug/mL
Compound 3 gave a limit, no number; the forecaster's own chance of this, stated with the estimate: 65%; the middle value is on the limit's open side.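

In this assay, compound 3 also gives only a limit, so no step can be read from compound 1 or compound 2 to compound 3. The compounds shown leave open where the actual solubility of any of the three lies.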